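The source may hold more compounds than are shown below. What is called first, only, known or untested is meant among the compounds shown, and "the series" means these compounds.

The measured compounds:

Compound 1, `Nc1cccc2c(-c3cccc(NC(=O)c4ccc(Cl)c(C(F)(F)F)c4)c3)ccnc12`, gives in a functional assay on SK-MEL-28 cells (Homo sapiens) for antiproliferative activity, read by sulforhodamine B assay, with a stated time of 48 h (on this read-out lower numbers stand for stronger inhibition and higher numbers for weaker inhibition), a value of 2900 nM.
Compound 2, `Nc1cccc2c(-c3cccc(NC(=O)c4ccc5c(c4)OCCO5)c3)ccnc12`, gives in this assay a value of 85 nM.
Compound 3, `COc1ccc(C(=O)Nc2cccc(-c3ccnc4c(NC(C)=O)cccc34)c2)cc1OC`, gives in this assay a value of 2700 nM.

Among these three numbers compound 3 stands second highest. Its nearest neighbour is compound 1, whose number lies within the usual scatter of it, so the two cannot be told apart. Its furthest neighbour is compound 2, which sits well beyond the scatter and carries a far lower number, that is, the stronger inhibition of the set. Compound 2 and compound 3 differ in more than one place, so their two values show a large gap without saying which change carries it.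

Compound 4, `CC(=O)Nc1cccc2c(-c3cccc(NC(=O)c4ccc5c(c4)OCCO5)c3)ccnc12`, is not yet measured. It differs from compound 3 in one place: 2,3-dihydro-1,4-benzodioxin-6-yl in place of 3,4-dimethoxyphenyl on a carbonyl carbon. Going by the values given here, the group that leaves and the group that enters are of the same size and carry the same count of acceptors; the entering group is the one that compound 2 also bears on its carbonyl carbon, where compound 2 gives 85 nM.

Among the compounds with values here, no step between measured compounds isolates this change. In this assay a moderate step toward a lower number is expected, within the range of a few-unit shift rather than a leap. The step from compound 3 to compound 4 is estimated at a 3.0-fold lower number from compound 3 to compound 4 (0.48 log units; beyond the scatter). Compound 4 is therefore expected to give about 900 nM, with a plausible range from 150 nM to 5000 nM.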

Compound 4, half-maximal inhibitory concentration: > 20000 nM
Compound 4: no number, only a limit (the forecaster's own chance of this, stated with the estimate: 3%); middle value at least 22-fold (1.34 log units) away from the limit.
By their numbers in this assay, from the lowest: compound 2; then compounds 3 and 1 (each within the scatter of the next). At a limit, above all of these: compound 4.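

Compound 4 gives no number in this assay, only a limit: the limit of > 20000 nM in this assay, at which 1 of the 4 values shown sits. With acetyl on the nitrogen on an aromatic ring, placing 2,3-dihydro-1,4-benzodioxin-6-yl on the carbonyl carbon in place of 3,4-dimethoxyphenyl gives an at least 7.4-fold higher number from compound 3 to compound 4 (0.86 log units; beyond the scatter), so this group, which compound 2 also bears, does not bring a low number with it whatever else the molecule carries. With that group held fixed, acetyl in place of hydrogen on the nitrogen gives an at least 230-fold higher number from compound 2 to compound 4 (2.37 log units; beyond the scatter), which shows that the low number depends on what sits on that nitrogen as well as on the group at the carbonyl carbon.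

The compounds shown leave open whether the loss belongs to acetyl in particular or would also follow from another group on that nitrogen, such as a methyl or a formyl. Going by these compounds alone, they also leave open how 3,4-dimethoxyphenyl and 2,3-dihydro-1,4-benzodioxin-6-yl compare when the nitrogen carries only hydrogen, since the one step between them is read with acetyl in place.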